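This account rests on a few compounds, and the source may have more. Where it says the series, first, only, none or still open, it means among the compounds named here.

Compound 1 `CNC(=O)N1CCCc2ccc(NC(=O)c3ccc(-c4ccn(C)n4)cc3)cc21` is the stronger of the two measured compounds in a functional assay on MV4-11 cells (Homo sapiens) for antiproliferative activity, with a stated time of 6 days, tested at 6.25 uM (a lower number here means a weaker effect, a higher number a stronger effect of the compound at the concentration tested), where compound 1 gives 97%. Compound 2 `CNC(=O)N1CCCc2ccc(NC(=O)c3cccc(-c4cnn(S(C)(=O)=O)c4)c3)cc21` gives 18% in this assay, a far weaker effect, though the two differ in more than one place, so the numbers alone are all that is known. Compound 3 `CNC(=O)N1CCCc2ccc(NC(=O)c3ccc(-c4cnn(C)c4)cc3)cc21` keeps the shared core of compound 1 and differs only in one ring: 1-methyl-1H-pyrazol-4-yl in place of 1-methyl-1H-pyrazol-3-yl on an aromatic carbon. The step from compound 1 to compound 3 is expected to be small, possibly a modest weakening, a number 12 percentage points lower from compound 1 to compound 3 (beyond the scatter). Compound 3 is therefore estimated at 85%, within 55% to 99%.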

Compound 3, a percentage reported as inhibition, at one concentration (the size of the read-out at that concentration, not a potency): 94.4%
Beside the measured number, compound 3's estimate is 9.4 percentage points below it; the measured number falls inside the stated range.
By their numbers in this assay, from the lowest: compound 2; then compounds 3 and 1 (each within the scatter of the next).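

In this assay, putting 1-methyl-1H-pyrazol-4-yl in place of 1-methyl-1H-pyrazol-3-yl on this aromatic carbon gives a number 2.6 percentage points lower from compound 1 to compound 3 (within the scatter). This single-place comparison shows that this position tolerates the rearrangement of the same ring atoms, at least at the one concentration tested. Nothing shown here gives a reason for this result.

From the compounds shown here alone, whether the two compounds differ in potency remains open, since a read-out at one concentration does not measure it. Also open, going by these compounds, is how an amine or a carboxylic acid at this position would behave.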